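Removing drawn configuration from compound 3 to give compound 4

The source may report more compounds than this note shows. Statements on the series, on what has been measured and on what is new or still open speak of the compounds shown alone.

Compound 1 `Cc1cnc(OC[C@@]2(c3ccccc3)C[C@H]2C(=O)Nc2ccc(C#N)cn2)c(C)n1` gives 21 nM in an assay on isolated protein for binding affinity to Orexin receptor type 2 (Homo sapiens), read by radioligand binding; a lower number here means a stronger inhibitor, a higher number a weaker inhibitor. Compound 2 `Cc1nn(C)cc1OCC1(c2ccccc2)CC1C(=O)Nc1ccc(C#N)cn1`, drawn without configuration at its ring carbons, gives 204 nM in this assay. Compound 3 `CCn1cc(OC[C@]2(c3ccccc3)C[C@@H]2C(=O)Nc2ccc(C#N)cn2)c(C)n1` is reported only as a limit of this assay, > 2000 nM, and so stands at the weak end of the three, as noted in the limit of > 2000 nM in this assay, at which 1 of the 3 values shown sits. Compound 4 `CCn1cc(OCC2(c3ccccc3)CC2C(=O)Nc2ccc(C#N)cn2)c(C)n1` has not yet been measured. Compared with compound 3, (the two compounds have the same atoms and bonds; at least one stereo element is drawn with a configuration in one of them and without one in the other: 2 of 2 stereo elements differ; a stereocentre at a saturated ring carbon is drawn R in compound 3 and without a configuration in compound 4; a stereocentre at a saturated ring carbon is drawn S in compound 3 and without a configuration in compound 4). Because compound 3 is known only as the limit > 2000 nM, while compound 2, also drawn without configuration, gives 204 nM, a mixture such as compound 4 is expected to hold some of the binding that compound 3 alone lacks. The step from compound 3 to compound 4 is therefore expected to run toward stronger binding, by an at least 5.0-fold lower number from compound 3 to compound 4 (0.69 log units; beyond the scatter), though it may again end at the limit. For compound 4 the expected value in this assay is 400 nM, with a range from 100 nM to 2000 nM.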

Compound 4, inhibition constant: 10 nM
The estimate for compound 4 lay 40-fold (1.60 log units) above the measured number; the measured number lies below the stated range.
By their numbers in this assay, from the lowest: compound 4; then compound 1; then compound 2. At a limit, above all of these: compound 3.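

In this assay the value of compound 3, > 2000 nM, is a limit of the assay. The result gives an at least 200-fold lower number from compound 3 to compound 4 (2.30 log units; beyond the scatter) with no change in atoms or bonds, so binding at this receptor depends on configuration at the ring carbons, and the form drawn for compound 3 does not carry it; the only difference is this: the fact that one of compounds 3 and 4 is drawn with a defined configuration and the other without, at the place where they differ Among the compounds drawn without configuration, methyl in place of hydrogen on a saturated chain carbon bound to an aromatic nitrogen gives a 20-fold lower number from compound 2 to compound 4 (1.31 log units; beyond the scatter), so this small change on the chain also counts heavily.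

It remains open which single configuration accounts for the binding of compound 4. On these data alone, it is also open whether a propyl chain or a cyclopropyl group at the same nitrogen would hold or extend this gain.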